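A few compounds are considered here, and "the series" means these few. Any claim that something is new, unique, unknown or untested is made for them only; others in the source may bear on it.

Compound 3 `OC1CCN(Cc2ccccc2)CC1N1CCN(c2ccccc2)CC1` carries a benzyl group on the ring nitrogen of the shared core. In an assay on PC-12 cells for displacement of a labelled ligand from vesicular acetylcholine transporter (Homo sapiens) (a higher number here means a weaker inhibitor, a lower number a stronger inhibitor), compound 3 gives only a limit, > 100 nM. Its two companions stand no more clearly. Compound 1 `CCN1CCC(N2CCN(c3ccccc3)CC2)C(O)C1` gives only a limit in this assay, > 1000 nM. Compound 2 `C=CCN1CCC(N2CCN(c3ccccc3)CC2)C(O)C1` likewise gives only a limit, > 100 nM. For the measured compounds named here, the single readable step, a step that the two limits leave unreadable from compound 1 to compound 2, has no readable size because its ends are the limits the limit of > 1000 nM in this assay, at which 1 of the 3 values shown sits, and (the limit of > 100 nM in this assay, at which 2 of the 3 values shown sit).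

Compound 4 `OC1CCN(C/C=C/I)CC1N1CCN(c2ccccc2)CC1` differs from compound 3 by 2-iodoethenyl in place of phenyl on a saturated chain carbon bound to an amine nitrogen in a ring. Going by the values given here, no measured step touches this change, so the direction cannot be anchored. The expected step is a step that the limit leaves unreadable from compound 3 to compound 4, held close to no change. Compound 4 is estimated at 300 nM, between 50 nM and 3000 nM.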

Compound 4, half-maximal inhibitory concentration: > 100 nM
Compound 4 was reported as a limit; the forecaster's own chance of this, stated with the estimate: 50%; the middle value does not contradict the limit.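

Compound 4 gives only a limit in this assay, > 100 nM. Compound 3 is also a limit there, so the step between compound 3 and compound 4 cannot be read. The compounds shown leave open how the group on the ring nitrogen of the shared core affects inhibition.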